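Swapping cyclobutyl for benzyl on a shared core

The source may hold more compounds than are shown below. What is called first, only, known or untested is meant among the compounds shown, and "the series" means these compounds.

Compound 1 `CC(C)(C)c1nc(-c2ccc[nH]2)c2cc(C(N)=O)c(N)nc2n1`: 130000 nM
Compound 2 `CC(C)(C)c1ccc2c(N)c(C#N)c(N)nc2n1`: 14200 nM
Compound 3 `N#Cc1c(N)nc2nc(C3CCC3)ncc2c1N`: 217000 nM

In a physicochemical assay for solubility, in phosphate buffer, with a stated time of 18 h (a lower number here means a less soluble compound, a higher number a more soluble compound), compound 3 gives 217000 nM. Compound 1, at 130000 nM, lies within the scatter of compound 3. Compound 2, at 14200 nM, has the lower number, and its gap to compound 3 lies well beyond the scatter.

Compound 4 `N#Cc1c(N)nc2nc(Cc3ccccc3)ncc2c1N` has the same core as compound 3, with benzyl in place of cyclobutyl on an aromatic carbon, between two ring nitrogen atoms (benzyl in place of cyclobutyl on an aromatic carbon). Among the measured compounds shown here, no two measured compounds differ in one place only, so the data show no direct precedent for this change. The gap between compound 3 at 217000 nM and compound 2 at 14200 nM gives only a rough sense of how far values can spread in this assay. A fall beyond the scatter is expected here, and the estimated step is a 5.4-fold lower number from compound 3 to compound 4 (0.73 log units; beyond the scatter). The estimate for compound 4 is 40000 nM, with an expected range of 10000 nM to 120000 nM.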

Compound 4, solubility: 13000 nM
Beside the measured number, compound 4's estimate is 3.1-fold (0.49 log units) above it; low and high end bracket the measured number.
By their numbers in this assay, from the lowest: compounds 4 and 2 (each within the scatter of the next); then compounds 1 and 3 (each within the scatter of the next).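

Among the compounds shown here, compound 3 and compound 4 form the first pair here that differs in one place only, so this position, on an aromatic carbon between two ring nitrogen atoms, can now be read directly. In this assay, benzyl in place of cyclobutyl gives a 17-fold lower number from compound 3 to compound 4 (1.22 log units; beyond the scatter), a large step beyond the scatter, which shows that the number depends strongly on the group at this position when the shared core stays the same. No measurement here gives a reason for this fall.

Benzyl differs from cyclobutyl both in its carbon count and in its aromatic ring, and this single pair cannot tell these two differences apart. On these data alone, both groups contain carbon only, so what a carboxylic acid or an amine at this position would do remains open.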